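This account rests on a few compounds, and the source may have more. Where it says the series, first, only, none or still open, it means among the compounds named here.

Three acylguanidines share the core of compound 1 `CS(=O)(=O)c1cc(C(=O)N=C(N)N)c(F)cc1F` and differ only in the substituents on the aromatic ring. In a functional assay for inhibition of sodium/hydrogen exchanger (Oryctolagus cuniculus) (a lower number here means a stronger inhibitor, a higher number a weaker inhibitor), compound 1 gives 630 nM. Compound 2 `Cc1cc(C2CCCCC2)c(S(C)(=O)=O)cc1C(=O)N=C(N)N` gives 22 nM in this assay, the lowest of the three numbers; compound 3 `CCc1cc(OC)c(S(C)(=O)=O)cc1C(=O)N=C(N)N` gives 30 nM, a number within the scatter of compound 2, while compound 1 stands beyond the scatter above both. Compound 4 `Cc1cc(OC(C)C)c(S(C)(=O)=O)cc1C(=O)N=C(N)N` is not yet measured. It differs from compound 2 by isopropoxy in place of cyclohexyl on an aromatic carbon. Compound 3 shows that an alkoxy group on this carbon is compatible with a low number, so the step of a 1.4-fold higher number from compound 2 to compound 4 (0.13 log units; within the scatter) is expected to stay within the scatter, with no clear direction. Compound 4 is estimated at 30 nM, within 12 nM to 80 nM.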

Compound 4, half-maximal inhibitory concentration: 19 nM
Beside the measured number, compound 4's estimate is 1.6-fold (0.20 log units) above it; measured number inside the range.
By their numbers in this assay, from the lowest: compounds 4, 2 and 3 (each within the scatter of the next); then compound 1.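

In this assay the exchange of cyclohexyl for isopropoxy is a 1.2-fold lower number from compound 2 to compound 4 (0.06 log units; within the scatter) and so gives no readable difference. On this aromatic carbon, with the methyl and methylsulfonyl groups held constant, a carbon ring and an open branched alkoxy group therefore read alike, and the ring is not needed for a low number. No measurement at hand bears on why these two groups read alike.

Open, going by these compounds, is how this carbon responds to an amine, a carboxylic acid or a longer alkoxy chain. On these data alone, whether any group here moves the number beyond the scatter also remains open.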